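The compounds below may be only part of what the source reports. "The series", "measured", "known", "first", "only" and "open" are said of these compounds alone.

Compound 3 `O=C(c1ccc(F)cc1)c1ccn(-c2ccc3c(c2)B(O)OC3)c1` was tested in an ADME assay on L929 cells (Mus musculus) for cytotoxicity, read by resazurin assay, with a stated time of 72 h; a higher number here means a weaker inhibitor, a lower number a stronger inhibitor. In this assay compound 3 gives only a limit of > 10 ug/mL, so no exact number is known for it. Two related compounds stand the same way. Compound 1 `COc1ccc(Sc2cn(-c3ccc4c(c3)B(O)OC4)c3ccccc23)cc1` also gives a limit of > 10 ug/mL in this assay. Compound 2 `O=C(NC1CCCCC1)c1cccn1-c1ccc2c(c1)B(O)OC2` likewise gives a limit of > 10 ug/mL in this assay. The picture so far is therefore (the limit of > 10 ug/mL in this assay, at which 3 of the 3 values shown sit). Compound 4 `CCc1ccc(C(=O)c2ccn(-c3ccc4c(c3)B(O)OC4)c2)cc1` differs from compound 3 by ethyl in place of fluoro on an aromatic carbon; the same difference, cut one bond further out, reads 4-fluorophenyl to 4-ethylphenyl. Within the data shown here, no measured pair shows such a step. The step that the limit leaves unreadable from compound 3 to compound 4 is expected to stay within the scatter. Compound 4 is thus estimated at 15 ug/mL, with a range of 7 ug/mL to 40 ug/mL, and most likely reported again as a limit.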

Compound 4, half-maximal inhibitory concentration: > 10 ug/mL
Compound 4 was reported as a limit (the forecaster's own chance of this, stated with the estimate: 80%); the middle value lies beyond the limit too.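

Compound 3 and compound 4 both stand only as limits in this assay, and no step can be read between them: the limit of > 10 ug/mL in this assay, at which 4 of the 4 values shown sit.

The compounds shown leave open the true value of each, and whether ethyl in place of fluoro changes anything.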